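Thiophene Replaces Trifluoromethylphenyl on the Hydrazone Carbon

A few compounds are considered here, and "the series" means these few. Any claim that something is new, unique, unknown or untested is made for them only; others in the source may bear on it.

Among the compounds with values here, in a functional assay on A549 cells (Homo sapiens) for antiproliferative activity, read by MTT assay (on this read-out lower numbers stand for stronger inhibition and higher numbers for weaker inhibition), compound 2 `Cn1c(=O)c(=O)n(C2CCCC2)c2nc(N/N=C/c3ccc(C(F)(F)F)cc3)ncc21` gives 40600 nM; its only neighbour so far, compound 1 `Cc1cccc(/C=N/Nc2ncc3c(n2)n(C2CCCC2)c(=O)c(=O)n3C)c1`, gives 34500 nM, and the two stand within the scatter of each other, as the step of a 1.2-fold higher number from compound 1 to compound 2 (0.07 log units; within the scatter) shows. Compound 3 `Cn1c(=O)c(=O)n(C2CCCC2)c2nc(N/N=C/c3cccs3)ncc21` differs from compound 2 by thiophen-2-yl in place of 4-(trifluoromethyl)phenyl on a carbon with a double bond to nitrogen. Within the data shown here, the one measured step, an exchange of one aryl group for another on this same carbon, stayed within the scatter, so the step of a 1.1-fold lower number from compound 2 to compound 3 (0.03 log units; within the scatter) is expected to stay within the scatter as well. Compound 3 is therefore estimated at 38000 nM, with a range from 15000 nM to 95000 nM.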

Compound 3, half-maximal inhibitory concentration: > 100000 nM
Compound 3: only a limit was reported; the forecaster's own chance of this, stated with the estimate: 10%; middle value at least 2.6-fold (0.42 log units) from the limit.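

On the carbon with a double bond to nitrogen, the aryl groups are not interchangeable: in this assay the change to thiophen-2-yl brings an at least 2.4-fold higher number from compound 2 to compound 3 (0.39 log units; beyond the scatter) and an at least 2.8-fold higher number from compound 1 to compound 3 (0.46 log units; beyond the scatter). Within the data shown here, by contrast, 4-(trifluoromethyl)phenyl and 3-methylphenyl stand within the scatter of each other, so thiophen-2-yl is the first group here to shift the read-out beyond it, towards weaker inhibition. The reading for compound 3 is a limit of the assay and not a number: the limit of > 100000 nM in this assay, at which 1 of the 3 values shown sits.

As far as these compounds go, how far compound 3 lies past that limit stays open. Also open, from the compounds shown here alone, is how this position would respond to an amine, a carboxylic acid or a longer chain.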